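Epoxide in place of nitrile on the bis(trifluoromethyl)phenyl core

This account rests on a few compounds, and the source may have more. Where it says the series, first, only, none or still open, it means among the compounds named here.

Measured so far:
compound 1 `O=C1C=CC(=O)N1c1cc(C(F)(F)F)cc(C(F)(F)F)c1`: < 0.017 h
compound 2 `N#Cc1cc(C(F)(F)F)cc(C(F)(F)F)c1`: > 50 h

In an ADME assay for pharmacokinetics, read by LC-MS, in phosphate buffer, with a stated time of 72 h, at pH 7.4, tested at 250 uM (on this read-out higher numbers stand for a longer-lived compound and lower numbers for a shorter-lived compound), compound 2 sits at a limit of the assay, (the limit of > 50 h in this assay, at which 1 of the 2 values shown sits), not at a number. Compound 1 likewise sits at a limit, (the limit of < 0.017 h in this assay, at which 1 of the 2 values shown sits). Among the measured compounds shown here, the only measured step, an at least 2900-fold higher number from compound 1 to compound 2 (3.46 log units; beyond the scatter), replaces a different group and does not cover the present change. Compound 3 `FC(F)(F)c1cc(C2CO2)cc(C(F)(F)F)c1` differs from compound 2 by oxiran-2-yl in place of cyano on an aromatic carbon. For the measured compounds named here, with no measured step bearing on this exchange, the step of an at least 1.2-fold lower number from compound 2 to compound 3 (0.09 log units; that floor lies within the scatter) is an expectation only, and compound 3 is estimated at 40 h, ranging from 5 h to 200 h.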

Compound 3, half-life: > 50 h
Compound 3: a limit, no number; the forecaster's own chance of this, stated with the estimate: 40%; at least 1.2-fold (0.09 log units) between middle value and limit.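

In this assay oxiran-2-yl on this aromatic carbon leaves compound 3 at a limit and not at a number, the same limit that compound 2 reaches with cyano: the limit of > 50 h in this assay, at which 2 of the 3 values shown sit. The core of compound 1 now stands apart from a second group at this place, with an at least 2900-fold higher number from compound 1 to compound 3 (3.46 log units; beyond the scatter) as the measured step. The step between compound 2 and compound 3 cannot be read. Any order of these two in half-life stays open, as does the result for an amine or a carboxylic acid on this aromatic carbon.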